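Anilide in place of the acid on the thiazole-free carbonyl

This account rests on a few compounds, and the source may have more. Where it says the series, first, only, none or still open, it means among the compounds named here.

Measured compounds:
compound 1 `CCOC(=O)c1sc(-c2nc3ccccc3n2C(C)C)nc1C` — > 20000 nM
compound 2 `CCOC(=O)c1csc(-c2nc3ccccc3n2Cc2ccccc2)n1` — 13000 nM
compound 3 `Cc1nc(-c2nc3ccccc3n2Cc2ccccc2)sc1C(=O)O` — 15300 nM

The series is read in a functional assay on SMMC-7721 cells (Homo sapiens) for cytotoxicity, read by MTT assay, with a stated time of 24 h; a higher number here means a weaker inhibitor, a lower number a stronger inhibitor. Compound 1 `CCOC(=O)c1sc(-c2nc3ccccc3n2C(C)C)nc1C` gives > 20000 nM in this assay, which is a limit of the assay and not a number (the limit of > 20000 nM in this assay, at which 1 of the 3 values shown sits). Compound 2 `CCOC(=O)c1csc(-c2nc3ccccc3n2Cc2ccccc2)n1` gives 13000 nM. Compound 3 `Cc1nc(-c2nc3ccccc3n2Cc2ccccc2)sc1C(=O)O` gives 15300 nM; the gap to compound 2 is within the scatter, so the two are not ordered against each other. Compound 3 therefore stands among the two numbers, with one further value only a limit.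

Compound 4 `Cc1nc(-c2nc3ccccc3n2Cc2ccccc2)sc1C(=O)Nc1ccccc1` is not yet measured in this assay. Against compound 3 the change is anilino in place of hydroxy on a carbonyl carbon — anilino in place of hydroxy on a carbonyl carbon. Among the measured compounds shown here, no measured pair covers a change of this kind, so the direction is open. The step from compound 3 to compound 4 is expected to be a 2.6-fold lower number from compound 3 to compound 4 (0.41 log units; beyond the scatter), modest and toward a lower number, though a result within the scatter is not excluded. Compound 4 is estimated at 6000 nM, in the range 1500 nM to 20000 nM.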

Compound 4, half-maximal inhibitory concentration: 3700 nM
The estimate for compound 4 lay 1.6-fold (0.21 log units) above the measured number, and the stated range covers the measured number.
By their numbers in this assay, from the lowest: compound 4; then compounds 2 and 3 (each within the scatter of the next). At a limit, above all of these: compound 1.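

In this assay, among the compounds shown here, the carbonyl carbon gives the first step between compounds that differ in one place: a 4.1-fold lower number from compound 3 to compound 4 (0.62 log units; beyond the scatter), with anilino in place of hydroxy. This shows that the number responds to the group on this carbonyl carbon, and that the larger, ring-bearing anilino is tolerated there rather than lost to the limit. No measured property in hand accounts for the size or direction of this step.

Still open, from the compounds shown here alone, is whether the step depends on the aromatic ring or on the carbonyl amide alone, a question that methylamino or cyclohexylamino on the same carbonyl carbon would address. Also open, going by these compounds, is how far the number moves with substituted anilino groups, such as a chloroanilino or a methoxyanilino, and whether an ethoxy at this carbonyl carbon would behave like hydroxy or anilino.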